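Replacing a bromo group with a methyl group

A few compounds are considered here, and "the series" means these few. Any claim that something is new, unique, unknown or untested is made for them only; others in the source may bear on it.

In a functional assay on NFS-60 cells (Mus musculus) for inhibition, with a stated time of 72 h (on this read-out higher numbers stand for weaker inhibition of growth and lower numbers for stronger inhibition of growth), compound 1 `COc1ccc(Cn2nc(Br)c3c(NC(=O)c4csc5c(N)ncnc45)cccc32)cc1` gives 2390 nM while compound 2 `Nc1ncnc2c(C(=O)Nc3cccc4c3c(Br)nn4Cc3cccc(Br)n3)csc12` gives 243 nM and so stands lowest of the two. Compound 3 `Cc1cccc(Cn2nc(Br)c3c(NC(=O)c4csc5c(N)ncnc45)cccc32)n1` carries methyl in place of bromo on an aromatic carbon and is not yet measured. Within the data shown here, the one measured step of a 9.8-fold lower number from compound 1 to compound 2 (0.99 log units; beyond the scatter) came with 6-bromopyridin-2-yl in place of 4-methoxyphenyl and exchanged a whole group, so it only loosely guides this smaller change. A smaller step is expected in this assay here, towards a slightly higher number and perhaps none beyond the scatter. The estimate is a modest one (a 1.3-fold higher number from compound 2 to compound 3 (0.12 log units; within the scatter)). Compound 3 is expected at 320 nM (range 110 nM to 950 nM).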

Compound 3, concentration for 50% growth inhibition: 27.5 nM
Beside the measured number, compound 3's estimate is 12-fold (1.07 log units) above it; measured number outside the range, below it.
By their numbers in this assay, from the lowest: compound 3; then compound 2; then compound 1.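

In this assay, methyl in place of bromo on the ring carbon next to the ring nitrogen lowers the number markedly (an 8.8-fold lower number from compound 2 to compound 3 (0.95 log units; beyond the scatter)), although each group counts one heavy atom, so this single position responds strongly to the group it carries. The full change from 4-methoxyphenyl to 6-methylpyridin-2-yl gives a large step (an 87-fold lower number from compound 1 to compound 3 (1.94 log units; beyond the scatter)). Nothing measured here explains why methyl outperforms bromo.

As far as these compounds go, whether chloro, ethyl or an amine at this position would match methyl remains open. So does whether a longer chain would lower the number further.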